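Adding a further methoxy to compound 2

The source may report more compounds than this note shows. Statements on the series, on what has been measured and on what is new or still open speak of the compounds shown alone.

Of the compounds shown here, three sharing one core have been measured so far. In a functional assay on K562 cells (Homo sapiens) for cytotoxicity, read by MTT assay, with a stated time of 24 h (a higher number here means a weaker inhibitor, a lower number a stronger inhibitor), compound 1 (`COc1ccc(/C=C2\CN(C)C/C(=C\c3ccccc3F)C2=O)cc1`) gives 18400 nM and compound 2 (`COc1ccc(/C=C2\CN(C)C/C(=C\c3ccccc3F)C2=O)cc1OC`) gives 18000 nM, so these two stand level within the scatter. Compound 3 (`COc1cc(/C=C2\CN(C)C/C(=C\c3ccccc3F)C2=O)cc(OC)c1`) gives 6320 nM, a lower number than compound 2 by more than the scatter.

The next compound is compound 4 (`COc1cc(/C=C2\CN(C)C/C(=C\c3ccccc3F)C2=O)cc(OC)c1OC`), which differs from compound 2 by one change: methoxy in place of hydrogen on an aromatic carbon. The new methoxy takes the place of a hydrogen on an aromatic carbon, and compound 4 then carries every methoxy group found in compound 2 and in compound 3.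

Going by the values given here, only one measured step is of the same kind, and it was a 1.0-fold lower number from compound 1 to compound 2 (0.01 log units; within the scatter). On that evidence, adding a methoxy need not move the number at all. Against this, compound 3 at 6320 nM shows that a different methoxy arrangement on this core can lower it. Taken together, these point to a small move toward a lower number in this assay, and the expected change is a 1.8-fold lower number from compound 2 to compound 4 (0.26 log units; within the scatter). For compound 4 the estimated value is 10000 nM, with an expected range from 4000 nM to 22000 nM.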

Compound 4, half-maximal inhibitory concentration: 4340 nM
Beside the measured number, compound 4's estimate is 2.3-fold (0.36 log units) above it; the range from low to high includes it.
By their numbers in this assay, from the lowest: compounds 4 and 3 (each within the scatter of the next); then compounds 2 and 1 (each within the scatter of the next).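

In this assay this position proves able to move the number, which the earlier step of the same kind gave no sign of: a methoxy placed ortho to a methoxy group and meta to a large group gives a 4.1-fold lower number from compound 2 to compound 4 (0.62 log units; beyond the scatter) and so crosses the scatter. Going by these compounds alone, the same swap of hydrogen for methoxy at another place on this ring gives a 1.5-fold lower number from compound 3 to compound 4 (0.16 log units; within the scatter) and stays within the scatter, so adding a methoxy does not by itself shift the number, and compound 2 to compound 4 is the one step of this kind that goes against a flat picture. The two flat steps also agree with each other, even though they sit on different cores: the same change on two cores in this assay, a 1.0-fold lower number (0.01 log units; within the scatter) from compound 1 to compound 2 and a 1.5-fold lower number (0.16 log units; within the scatter) from compound 3 to compound 4, 1.4-fold (0.15 log units) apart, within the scatter of two such steps.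

From the compounds shown here alone, what remains open is whether the shift belongs to methoxy itself or would also follow from another group at this position, such as a hydroxyl, a chlorine, an amine or the longer ethoxy chain. Also open, going by these compounds, is whether the step would hold if the fluorine on the other aromatic ring gave way to hydrogen or to a chlorine.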